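This account rests on a few compounds, and the source may have more. Where it says the series, first, only, none or still open, it means among the compounds named here.

Compound 1 `COc1cc(-c2ncnn2-c2cccc(F)c2)cc(OC)c1OC` stands only at a limit in a functional assay on Jurkat cells (Homo sapiens) for antiproliferative activity, read by MTT assay, with a stated time of 72 h; a lower number here means a stronger inhibitor, a higher number a weaker inhibitor: compound 1 gives > 10000 nM, which is a limit of the assay and not a number. Going by the values given here, compound 2 `COc1cc(-c2ncnn2-c2ccc(Cl)cc2)cc(OC)c1OC` is the one measured neighbour. In this assay compound 2 likewise gives > 10000 nM, again a limit. Among the compounds with values here, the single measured step, a step that the two limits leave unreadable from compound 1 to compound 2, bears on the question only in that (the limit of > 10000 nM in this assay, at which 2 of the 2 values shown sit). Compound 3 `COc1cc(-c2ncnn2-c2cccc([N+](=O)[O-])c2)cc(OC)c1OC` differs from compound 1 by nitro in place of fluoro on an aromatic carbon. With both measured values sitting at the limit, no size of step can be read, and compound 3 is expected to stay there, the expected step being a step that the limit leaves unreadable from compound 1 to compound 3. The estimate for compound 3 in this assay is 15000 nM, within 5000 nM to 50000 nM.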

Compound 3, half-maximal inhibitory concentration: > 10000 nM
Compound 3: only a limit was reported; the forecaster's own chance of this, stated with the estimate: 75%; the middle value does not contradict the limit.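

Going by these compounds alone, compound 3 gives only a limit, as compound 1 does, so no step between compound 1 and compound 3 can be read: the limit of > 10000 nM in this assay, at which 3 of the 3 values shown sit. The compounds shown leave open which change, if any, would give a measurable value in this assay.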